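This account rests on a few compounds, and the source may have more. Where it says the series, first, only, none or still open, it means among the compounds named here.

Measured so far:
compound 1 `Fc1cccc(NC(=S)N/N=C/c2ccc3ccccc3n2)c1` — 79900 nM
compound 2 `NC(=S)N/N=C/c1nc2ccccc2s1` — > 100000 nM

For the measured compounds named here, in a functional assay on SGC-7901 cells (Homo sapiens) for antiproliferative activity, read by sulforhodamine B assay, with a stated time of 72 h (a lower number here means a stronger inhibitor, a higher number a weaker inhibitor), compound 1 gives 79900 nM, the only plain number in this set. Compound 2 gives > 100000 nM, which is a limit of the assay and not a number (the limit of > 100000 nM in this assay, at which 1 of the 2 values shown sits). Compound 3 `S=C(N/N=C/c1ccc2ccccc2n1)Nc1ccccc1` differs from compound 1 in one place: hydrogen in place of fluoro on an aromatic carbon. Going by the values given here, no step between two measured compounds is available to guide this change, so the expected step of a 1.0-fold higher number from compound 1 to compound 3 (0.00 log units; within the scatter) is small and within the usual scatter. Compound 3 is therefore expected to give about 80000 nM, somewhere between 30000 nM and 200000 nM.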

Compound 3, half-maximal inhibitory concentration: 26500 nM
Compound 3: middle estimate off by 3.0-fold (0.48 log units), on the high side; the whole stated range lies above it.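

Going from 3-fluorophenyl to phenyl in this assay gives a 3.0-fold lower number from compound 1 to compound 3 (0.48 log units; beyond the scatter) and so provides the first readable step in this set. It shows that this aromatic carbon responds to what it carries, and that here hydrogen gives the stronger inhibitor of the pair. Nothing shown gives a measured property that bears on this step.

Only fluoro and hydrogen are compared at this position. A chlorine atom, a methoxy group or an amine there could give a stronger or a weaker inhibitor than either.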